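The compounds below may be only part of what the source reports. "The series", "measured", "known", "first", "only" and "open" are said of these compounds alone.

Measured so far:
- compound 1 `CC1=CC[C@H](NC(=O)c2ccc3ccccc3c2)C(=O)N(CC(=O)N[C@H]2CC(=O)OC2O)C1`: 153 nM
- compound 2 `O=C(CN1CC(CO)=CC[C@H](NC(=O)c2ccc3ccccc3c2)C1=O)N[C@H]1CC(=O)OC1O`: 543 nM

Both values come from a functional assay on THP-1 cells (Homo sapiens) for inhibition; a higher number here means a weaker inhibitor, a lower number a stronger inhibitor. Of the two measured compounds, compound 2 has the higher number, at 543 nM. Compound 3 `O=C(CN1CC=CC[C@H](NC(=O)c2ccc3ccccc3c2)C1=O)N[C@H]1CC(=O)OC1O` differs from it by hydrogen in place of hydroxymethyl on a double-bonded ring carbon, with hydrogen in place of hydroxymethyl on a double-bonded ring carbon. Among the compounds with values here, one measured step bears on this: a 3.5-fold higher number from compound 1 to compound 2 (0.55 log units; beyond the scatter), where hydroxy replaced hydrogen on a saturated chain carbon. That change is not the same one, so it guides only loosely, but a lower number in this assay is expected, of similar or smaller size. The expected step is a 2.1-fold lower number from compound 2 to compound 3 (0.32 log units; beyond the scatter). The estimate for compound 3 is 260 nM, within an expected range of 100 nM to 600 nM.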

Compound 3, half-maximal inhibitory concentration: 100 nM
Estimate against measurement, compound 3: 2.6-fold (0.41 log units) above; the range from low to high includes it.
By their numbers in this assay, from the lowest: compounds 3 and 1 (each within the scatter of the next); then compound 2.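

Within this assay hydrogen in place of hydroxymethyl on the double-bonded ring carbon gives a clear change (a 5.4-fold lower number from compound 2 to compound 3 (0.73 log units; beyond the scatter)), whereas hydrogen in place of methyl on that carbon does not (a 1.5-fold lower number from compound 1 to compound 3 (0.18 log units; within the scatter)). At this position, hydrogen and methyl cannot be told apart, and compound 2 with its hydroxymethyl group stands alone among the three. Nothing available explains this difference. The compounds shown leave open how an amine, a carboxylic acid or a longer chain on this carbon would read.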